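Moving the Aniline Amino Group on a Weak Cytotoxic Lead

A few compounds are considered here, and "the series" means these few. Any claim that something is new, unique, unknown or untested is made for them only; others in the source may bear on it.

This account concerns a small series of amide-bearing compounds built on a shared core and tested in a functional assay on HCT-116 cells (Homo sapiens) for cytotoxicity, read by MTT assay, with a stated time of 72 h; on this read-out lower numbers stand for stronger inhibition and higher numbers for weaker inhibition. Among the measured compounds shown here, compound 1, with the structure `Nc1ccc(Nc2c(C(=O)NCc3ccc(F)cc3)nc(Br)c3cccnc23)cc1`, is the only member of the group for which a number exists: in this assay compound 1 gives 10000 nM, a weak result. Two related compounds were also prepared. Compound 2, `O=C(NCc1ccc(F)cc1)c1nc(NCCO)c2cccnc2c1O`, was entered into this assay, where compound 2 gives "not determined" (no result reported). Compound 3, `N[C@H]1CC[C@H](Nc2c(C(=O)NCc3cccs3)nc(Br)c3cccnc23)CC1`, was likewise entered into this assay, where compound 3 gives "not determined" (no result reported). Neither of them therefore offers a comparison.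

The step under consideration leads from compound 1 to compound 4, whose structure is `Nc1cccc(Nc2c(C(=O)NCc3ccc(F)cc3)nc(Br)c3cccnc23)c1`. The change is 3-aminophenyl in place of 4-aminophenyl on a nitrogen on an aromatic ring. The two compounds contain the same atoms, joined differently, and the only alteration is the point at which the amino group sits on the phenyl ring attached to the nitrogen on the aromatic ring of the core.

For the measured compounds named here, no comparable step between measured compounds is available to guide expectations, and the starting value for compound 1 is already weak. The author therefore expects the step of no change at the digits printed from compound 1 to compound 4 (within the scatter) to be no larger than the scatter of repeated measurements, in either direction. Compound 4 is estimated to give 10000 nM in this assay, with a likely range of 4000 nM to 25000 nM.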

Compound 4, half-maximal inhibitory concentration: > 10000 nM
Compound 4 ended at the assay's limit (the forecaster's own chance of this, stated with the estimate: 40%); the middle value sits exactly at the limit.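

In this assay, moving the amino group on the phenyl ring gives a number no lower from compound 1 to compound 4 (the limit leaves the size open). For compound 4, the value > 10000 nM is a limit of the assay and not a number. The step from 4-aminophenyl to 3-aminophenyl on a nitrogen on an aromatic ring therefore gives no sign of stronger inhibition, which the single value of compound 1 could not show, but how far compound 4 lies from compound 1 cannot be read: the limit of > 10000 nM in this assay, at which 1 of the 4 values shown sits.

The compounds shown leave open whether any other group at this place would bring the series to a readable value in this assay, for instance a phenyl ring carrying a carboxylic acid or an aminomethyl group instead of the amino group. They also leave open whether a longer chain between the phenyl ring and the amino group would change the outcome, so nothing here yet says how much the read-out depends on this part of the molecule.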